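An Aromatic Group Swap on Compound 3

The source may report more compounds than this note shows. Statements on the series, on what has been measured and on what is new or still open speak of the compounds shown alone.

In a functional assay on MCF7 cells (Homo sapiens) for inhibition, with a stated time of 72 h (on this read-out lower numbers stand for stronger inhibition and higher numbers for weaker inhibition), compound 1 `NC1CCC(Nc2nc(NCc3ccc(Br)cc3)c3ncn(C4CCCC4)c3n2)CC1` gives 850 nM, compound 2 `NC1CCC(Nc2nc(NCc3ccc(-c4ccccc4)cc3)c3ncn(C4CCCC4)c3n2)CC1` gives 583 nM, and compound 3 `NC1CCC(Nc2nc(NCc3ccc(-c4cccc(F)c4)nc3)c3ncn(C4CCCC4)c3n2)CC1` gives 33 nM, the lowest of these three numbers. Compound 4 `NC1CCC(Nc2nc(NCc3ccc(-c4cccs4)nc3)c3ncn(C4CCCC4)c3n2)CC1` differs from compound 3 in one place, with thiophen-2-yl in place of 3-fluorophenyl on an aromatic carbon. Among the compounds with values here, only one measured step changes a single place, a 1.5-fold lower number from compound 1 to compound 2 (0.16 log units; within the scatter), where phenyl replaced bromo, and it stayed within the scatter. That single step is thin evidence, but it gives no reason to expect a large shift in this assay from this swap, and no clear direction. The expected change is a 1.4-fold higher number from compound 3 to compound 4 (0.13 log units; within the scatter), which would stay within the scatter. For compound 4 the estimated value is 45 nM, with an expected range of 15 nM to 140 nM.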

Compound 4, half-maximal inhibitory concentration: 92 nM
Beside the measured number, compound 4's estimate is 2.0-fold (0.31 log units) below it; the measured number falls inside the stated range.
By their numbers in this assay, from the lowest: compound 3; then compound 4; then compounds 2 and 1 (each within the scatter of the next).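

Within the data shown here, at this position, on the aromatic carbon next to the ring nitrogen, the earlier compounds gave no view of how much the attached ring matters: thiophen-2-yl in place of 3-fluorophenyl gives a 2.8-fold higher number from compound 3 to compound 4 (0.45 log units; beyond the scatter) in this assay. Even so, compound 4 keeps a clear lead over the two compounds without the pyridine, with a 6.3-fold lower number from compound 2 to compound 4 (0.80 log units; beyond the scatter) and a 9.2-fold lower number from compound 1 to compound 4 (0.97 log units; beyond the scatter). Nothing measured here gives a reason for these steps. As far as these compounds go, the swap changes ring size and removes the fluorine together, so which of the two matters stays open. A plain phenyl or an amine at this carbon would be the open cases.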